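Methyl-to-chloro swap on the pendant phenyl ring

The source may hold more compounds than are shown below. What is called first, only, known or untested is meant among the compounds shown, and "the series" means these compounds.

Measured in a functional assay on SGC-7901 cells (Homo sapiens) for antiproliferative activity, read by MTT assay, with a stated time of 72 h; on this read-out higher numbers stand for weaker inhibition and lower numbers for stronger inhibition:
compound 1, `COc1cc(-n2cnc3ccc(-c4cccc(Cl)c4)cc32)cc(OC)c1OC`, 1490 nM
compound 2, `COc1cc(-n2cnc3ccc(-c4cccc(C)c4)cc32)cc(OC)c1OC`, 1240 nM
compound 3, `COc1cc(-n2cnc3ccc(-c4ccc(C)cc4)cc32)cc(OC)c1OC`, 200 nM

The cores of compound 2 and compound 3 differ by 4-methylphenyl in place of 3-methylphenyl on an aromatic carbon; this gave a 6.2-fold lower number from compound 2 to compound 3 (0.79 log units; beyond the scatter). Compound 1 to compound 3 gave a 7.5-fold lower number from compound 1 to compound 3 (0.87 log units; beyond the scatter). On the core of compound 2, the change chloro in place of methyl on an aromatic carbon gave a 1.2-fold higher number from compound 2 to compound 1 (0.08 log units; within the scatter).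

Compound 4, `COc1cc(-n2cnc3ccc(-c4ccc(Cl)cc4)cc32)cc(OC)c1OC`, is not yet measured in this assay. It differs from compound 3 by chloro in place of methyl on an aromatic carbon. This is the same kind of change as that from compound 2 to compound 1, not the same change: there the chloro sits meta to a large group, here para to a large group, so the earlier step is only a guide.

Since compound 2 to compound 1 moved within the scatter, as a 1.2-fold higher number from compound 2 to compound 1 (0.08 log units; within the scatter) shows, compound 4 is expected to stay near compound 3, with an expected step of a 1.3-fold higher number from compound 3 to compound 4 (0.10 log units; within the scatter). Compound 4 is estimated at 250 nM, with a range from 120 nM to 600 nM.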

Compound 4, half-maximal inhibitory concentration: 1270 nM
The estimate for compound 4 lay 5.1-fold (0.71 log units) below the measured number, outside the stated range (above it).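

In this assay the swap of methyl for chloro does not carry over from one core to the other with the same size, so the step on one core is a poor guide to the step on the other: the same change on two cores in this assay, a 1.2-fold higher number (0.08 log units; within the scatter) from compound 2 to compound 1 and a 6.4-fold higher number (0.80 log units; beyond the scatter) from compound 3 to compound 4, 5.3-fold (0.72 log units) apart, beyond the scatter of two such steps

With a 6.4-fold higher number from compound 3 to compound 4 (0.80 log units; beyond the scatter) the low number stays with the 4-methylphenyl compound alone, while a 1.0-fold higher number from compound 2 to compound 4 (0.01 log units; within the scatter) and a 1.2-fold lower number from compound 1 to compound 4 (0.07 log units; within the scatter) leave no order among the other three compounds. This rests on a single pair on each core, so it shows that the change depends on where it is made in these four compounds, but it gives no reason for that and no rule for other cores.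

The compounds shown leave open whether the low number of compound 3 belongs to methyl in particular or would also appear with an ethyl, a methoxy or an amine para to a large group. They also leave open whether a fluoro or a bromo in that place would follow the chloro of compound 4 or the methyl of compound 3.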